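The compounds below may be only part of what the source reports. "The series", "measured", "known", "first", "only" and "open" are said of these compounds alone.

compound 1 `COc1cc(/C=N/NC(=O)CCCc2nc3ccccc3c(=O)[nH]2)cc(O)c1O` gives 88000000 nM
compound 2 `O=C(CCCc1nc2ccccc2c(=O)[nH]1)N/N=C/c1ccc([N+](=O)[O-])cc1` gives 316000000 nM
compound 3 `O=C(CCc1nc2ccccc2c(=O)[nH]1)N/N=C/c1cc(O)c(O)c(O)c1` gives 81000000 nM

All three values come from a single test (a physicochemical assay, read by spectrophotometry, with a stated time of 30 min; a lower number here means a stronger inhibitor, a higher number a weaker inhibitor). Compound 2 has the highest number of the three, which makes it the weakest inhibitor here. The other two compounds both sit lower by more than the usual scatter.

Compound 4 `O=C(CCCc1nc2ccccc2c(=O)[nH]1)N/N=C/c1ccc(O)c(O)c1` has not been measured yet. It keeps the chain and the shared core of compound 2, and the change is 3,4-dihydroxyphenyl in place of 4-nitrophenyl on a carbon with a double bond to nitrogen.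

For the measured compounds named here, no measured pair differs at this one place alone, so the size of the step cannot be read directly. The nearest guide is indirect: compound 1 at 88000000 nM and compound 3 at 81000000 nM both carry hydroxyl groups on the aromatic ring where compound 2 has its nitro group, although compound 3 also has a shorter chain. Going by the values given here, with only three compounds this is thin evidence, but it points towards a lower number, by more than the scatter, in this assay for the new compound. The step is expected to be of this size (a 4.0-fold lower number from compound 2 to compound 4 (0.60 log units; beyond the scatter)). For compound 4 the estimated value is 80000000 nM (expected range 30000000 nM to 200000000 nM).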

Compound 4, half-maximal inhibitory concentration: 95000000 nM
Compound 4: the middle estimate sits 1.2-fold (0.07 log units) below what was measured; measured number inside the range.
By their numbers in this assay, from the lowest: compounds 3, 1 and 4 (each within the scatter of the next); then compound 2.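

In this assay, putting 3,4-dihydroxyphenyl in place of 4-nitrophenyl on a carbon with a double bond to nitrogen gives a 3.3-fold lower number from compound 2 to compound 4 (0.52 log units; beyond the scatter), with the chain and the shared core left unchanged, so this change can now be read on its own. Hydrogen in place of methoxy on an aromatic carbon gives a 1.1-fold higher number from compound 1 to compound 4 (0.03 log units; within the scatter), which lies within the scatter, so this assay does not tell these two ring patterns apart, and the methoxy group shows no readable effect here. Nothing measured here accounts for the step away from 4-nitrophenyl.

As far as these compounds go, with only these ring groups on this chain, it remains open whether the lower number comes from gaining the hydroxyl groups or from losing the nitro group, a question that a plain phenyl ring or a ring carrying a single hydroxyl or an amine could help to settle. From the compounds shown here alone, it is also open how a longer chain between the shared core and the carbonyl would behave alongside 3,4-dihydroxyphenyl.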